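Swapping the amide aryl: 4-ethylphenyl to 3-nitrophenyl

The compounds below may be only part of what the source reports. "The series", "measured", "known", "first", "only" and "open" are said of these compounds alone.

Of the compounds shown here, three have been measured in an assay on isolated protein for inhibition of Rho-associated protein kinase 2 (Homo sapiens), read by scintillation counting, radiometric assay and 33P incorporation, with a stated time of 40 min, in the presence of a further agent that is not named here; a higher number here means a weaker inhibitor, a lower number a stronger inhibitor. Compound 1 `CN(C)c1ccc(C(=O)Nc2cccc(NC(=O)COc3ccc4c(c3)CCC(=O)N4)c2)cc1` gives 9970 nM, compound 2 `CC(=O)c1ccc(OCC(=O)Nc2cccc(NC(=O)c3ccc(N(C)C)cc3)c2)cc1F` gives 98 nM, and compound 3 `CCc1ccc(C(=O)Nc2cccc(NC(=O)COc3ccc4c(=O)ccoc4c3)c2)cc1` gives 24 nM, the lowest of the three and beyond the scatter against both others, so compound 3 is the most potent measured compound. Going by the values given here, the single step between compounds that differ in one place, a 100-fold lower number from compound 1 to compound 2 (2.01 log units; beyond the scatter), concerns the group on the oxygen of the saturated carbon, not the amide aryl ring.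

Compound 4 `O=C(COc1ccc2c(=O)ccoc2c1)Nc1cccc(NC(=O)c2cccc([N+](=O)[O-])c2)c1` is yet to be measured in this assay. It differs from compound 3 in that (3-nitrophenyl in place of 4-ethylphenyl on a carbonyl carbon). Among the compounds with values here, no measured step touches this position, so no direct guide exists; the step from compound 1 to compound 2 bears only on the other end of the molecule. A modest rise in the number is therefore expected for compound 4, a 3.3-fold higher number from compound 3 to compound 4 (0.52 log units; beyond the scatter), with wide uncertainty. In this assay compound 4 is estimated at 80 nM, with a range of 20 nM to 320 nM.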

Compound 4, half-maximal inhibitory concentration: 41 nM
Estimate against measurement, compound 4: 2.0-fold (0.29 log units) above; the measured number falls inside the stated range.
By their numbers in this assay, from the lowest: compounds 3 and 4 (each within the scatter of the next); then compound 2; then compound 1.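

Going by these compounds alone, the first measured step at this carbonyl carbon gives a 1.7-fold higher number from compound 3 to compound 4 (0.23 log units; within the scatter) in this assay, so the two compounds cannot be separated here. With the rest of the molecule unchanged, the position therefore accepts either 4-ethylphenyl or 3-nitrophenyl without a change that stands clear of the scatter, even though the two groups differ in both their substituent and its place on the ring. Nothing available explains why these two groups read alike.

On these data alone, it remains open whether a 4-nitrophenyl, 3-ethylphenyl, or plain phenyl group would read the same, which would separate the substituent from its place on the ring. As far as these compounds go, it is equally open whether an amine, a carboxylic acid or a longer alkyl chain on this ring would hold the number near these values.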